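Nitrile to Carboxylic Acid on the Ether Chain

This account rests on a few compounds, and the source may have more. Where it says the series, first, only, none or still open, it means among the compounds named here.

Compound 1, `CCCc1cc(C(C)=O)c(O)cc1OCCCCC#N`, is the starting point of this comparison. In an assay on isolated protein for binding affinity to leukotriene B4 receptor 1 (Homo sapiens), tested at 1 uM (on this read-out lower numbers stand for less inhibition and higher numbers for more inhibition at the one concentration tested (going by the name of the read-out)), compound 1 gives 37%, the lowest of the three numbers measured. Compound 2, `CCc1cc(C(C)=O)c(O)cc1OCCCCCC(C)(C)C#N`, gives 53% in this assay, and compound 3, `CCc1cc(C(C)=O)c(O)cc1OCCCCCC(C)(C)C(=O)O`, gives 73%. The difference between the core of compound 1 and the core of compound 2 is not broken down here. Compounds 2 and 3 differ in one place: carboxy in place of cyano on a saturated chain carbon bound to three saturated chain carbons. This change made a number 20 percentage points higher from compound 2 to compound 3 (beyond the scatter).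

Compound 4, `CCCc1cc(C(C)=O)c(O)cc1OCCCCC(=O)O`, has not yet been measured. It differs from compound 1 in one place: carboxy in place of cyano on a saturated chain carbon, four bonds along the chain from an oxygen on an aromatic ring. Among the measured compounds shown here, the replacement is the same kind of change as the one seen between compound 2 and compound 3, but not the same: in compound 3 the carboxy sits on a saturated chain carbon bound to three saturated chain carbons, whereas in compound 4 it sits on a saturated chain carbon, four bonds along the chain from an oxygen on an aromatic ring. Among the compounds shown, carboxy in place of cyano occurs two times in all.

For the measured compounds named here, for compound 4 in this assay a step of about a number 20 percentage points higher from compound 1 to compound 4 (beyond the scatter) is expected, beside the earlier one, because a number 20 percentage points higher from compound 2 to compound 3 (beyond the scatter) was measured for the one comparable pair. That expectation rests on a single pair with a differently surrounded place, so it is held loosely. Compound 4 is expected to give around 57% in this assay, with a range from 42% to 72%.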

Compound 4, a percentage reported as inhibition, at one concentration (the size of the read-out at that concentration, not a potency): 0%
Compound 4: middle estimate off by 57 percentage points, on the high side; the whole stated range lies above it.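

In this assay, exchanging cyano for carboxy on a saturated chain carbon, four bonds along the chain from an oxygen on an aromatic ring, gave a number 37 percentage points lower from compound 1 to compound 4 (beyond the scatter). Set beside the earlier step, the same exchange did not carry over from one core to the other, and its direction reversed: the same change on two cores in this assay, a number 20 percentage points higher (beyond the scatter) from compound 2 to compound 3 and a number 37 percentage points lower (beyond the scatter) from compound 1 to compound 4, 57 percentage points apart, beyond the scatter of two such steps

This shows that, within these two pairs, the step measured for compound 2 and compound 3 gives no reliable guide to the size or even the sign of the step for compound 1 and compound 4, so the exchange cannot be treated as a transferable increment in this series; it does not show which structural difference between the two pairs decides the outcome, as the pairs differ both in the core and in the chain that carries the group, and two pairs cannot separate these.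

The compounds shown leave open whether the reversal follows the chain or the rest of the core, a question that a longer chain ending in a carboxylic acid on the core of compound 1 would bear on. They also leave open how an amide or a tetrazole in the same place would behave on either core.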